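Solubility in the urea series: trimming benzyl to propyl

The compounds below may be only part of what the source reports. "The series", "measured", "known", "first", "only" and "open" are said of these compounds alone.

The compounds share a core in which the ring nitrogen carries an amide and the pyrazole amine carries either a urea or a benzamide. Compound 1 is `CN1CCC(C(=O)N2Cc3c(NC(=O)NCc4ccccc4)n[nH]c3C2(C)C)CC1`. In a physicochemical assay for solubility, at pH 7 (a higher number here means a more soluble compound, a lower number a less soluble compound), compound 1 gives > 225000 nM, which is a limit of the assay and not a number. Compound 2, `CC1(C)c2[nH]nc(NC(=O)c3ccc(F)cc3)c2CN1C(=O)C1CCN(C2CC2)CC1`, in this assay gives > 225000 nM, again a limit. Compound 3, `CC(C)(C)C(=O)N1Cc2c(NC(=O)c3ccc(F)cc3)n[nH]c2C1(C)C`, gives 235000 nM in this assay. The step that the limit leaves unreadable from compound 2 to compound 3 is therefore not readable as a size. Across the three values the picture is flat, with the limit of > 225000 nM in this assay, at which 2 of the 3 values shown sit, covering two of them and the third sitting at a similar level.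

Compound 4 is `CCCNC(=O)Nc1n[nH]c2c1CN(C(=O)C1CCN(C)CC1)C2(C)C`. It differs from compound 1 in one place: ethyl in place of phenyl on a saturated chain carbon bound to an amide-type nitrogen. Cut one bond further out, the change reads benzyl to propyl on the urea.

Among the compounds with values here, no measured step follows this particular change, and the one step measured gives no readable size. Compound 1 stands at the limit, so the direction of any step is hard to read. Compound 4 is expected to remain near that level, so the step that the limit leaves unreadable from compound 1 to compound 4 is estimated to be none beyond the scatter. For compound 4 the value in this assay is estimated at 250000 nM, within 150000 nM to 500000 nM, most probably reported as a limit again.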

Compound 4, solubility: > 225000 nM
Compound 4 was reported as a limit; the forecaster's own chance of this, stated with the estimate: 80%; the middle value lies beyond the limit too.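

In this assay compound 4 gives > 225000 nM, a limit of the assay and not a number. Within the data shown here, compound 1 also sits at a limit, and no step between compound 1 and compound 4 can be read. The compounds shown leave open how the compounds at the limit rank against one another: the limit of > 225000 nM in this assay, at which 3 of the 4 values shown sit.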